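Removing the fluoro from compound 1: expected cytotoxicity

The compounds below may be only part of what the source reports. "The series", "measured", "known", "first", "only" and "open" are said of these compounds alone.

Compound 1, `O=c1cc(-c2ccccc2)oc2c(-c3ccc(F)cc3)c(O)c(O)c(O)c12`: in a toxicity assay on Huh-7 cells (Homo sapiens) for cytotoxicity, read by CCK-8 assay, with a stated time of 24 h (on this read-out higher numbers stand for lower toxicity in this test and lower numbers for higher toxicity in this test), compound 1 gives > 100000 nM, which is a limit of the assay and not a number.
Compound 2, `Oc1c(O)c(O)c2c(=S)cc(-c3ccccc3)oc2c1-c1cccc(F)c1`: in this assay compound 2 gives > 100000 nM, again a limit.
Compound 3, `Oc1c(O)c(O)c2c(=S)cc(-c3ccccc3)oc2c1-c1ccc(C(F)(F)F)cc1`: in this assay compound 3 gives > 100000 nM, again a limit.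

Compound 1 therefore stands only at the limit, as do the other two compounds shown. Within the data shown here, the one measured step, a step that the two limits leave unreadable from compound 2 to compound 3, cannot be sized, since both of its values are limits; this is summed up by the limit of > 100000 nM in this assay, at which 3 of the 3 values shown sit. The compound to be measured is compound 4, `O=c1cc(-c2ccccc2)oc2c(-c3ccccc3)c(O)c(O)c(O)c12`. It differs from compound 1 in one place: hydrogen in place of fluoro on an aromatic carbon. Among the measured compounds shown here, no measured step bears directly on this change, and the step between compound 2 and compound 3 gives no readable size. The expectation for compound 4 is therefore that it, like compound 1, sits at the limit, with no step beyond the scatter expected in this assay, so that a step that the limit leaves unreadable from compound 1 to compound 4 is the estimated step. Compound 4 is estimated at 150000 nM, within 80000 nM to 400000 nM.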

Compound 4, half-maximal cytotoxic concentration: 86300 nM
Compound 4: the middle estimate sits 1.7-fold (0.24 log units) above what was measured; measured number inside the range.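

In this assay compound 4 gives 86300 nM, the first value among the compounds shown that is a number and not a limit. The change from 4-fluorophenyl to phenyl gives an at least 1.1-fold lower number from compound 1 to compound 4 (0.06 log units; that floor lies within the scatter), so only a floor can be read: the step is not shown to exceed the scatter, but a larger one is not ruled out. Compound 4 therefore places a measured value on this series, though most of the picture still rests on limits: the limit of > 100000 nM in this assay, at which 3 of the 4 values shown sit.

The step that joins two limits cannot be read, so the compounds shown do not tell how changes on this aromatic ring compare in size. Also open, on these data alone, is how an amine, a methoxy group or a carboxylic acid would read at this place in this assay.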